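This account rests on a few compounds, and the source may have more. Where it says the series, first, only, none or still open, it means among the compounds named here.

Three ureas share one core and differ only in the group on the phenyl ring at the far end of the urea. Compound 1 `O=C(Nc1ccccc1)Nc1ccc2c(c1)COC2=O` carries hydrogen there, and in a functional assay on cells (T-cell, Mus musculus) for inhibition (on this read-out lower numbers stand for stronger inhibition and higher numbers for weaker inhibition), compound 1 gives 7090 nM. Compound 2 `O=C(Nc1ccc(F)cc1)Nc1ccc2c(c1)COC2=O` carries fluoro, and in this assay compound 2 gives 4190 nM. Compound 3 `O=C(Nc1ccc(Cl)cc1)Nc1ccc2c(c1)COC2=O` carries chloro, and in this assay compound 3 gives 2450 nM, the lowest of the three numbers, although its gap to compound 2 stays within the scatter and only its gap to compound 1 lies beyond it. The measured steps are a 1.7-fold lower number from compound 1 to compound 2 (0.23 log units; within the scatter), a 2.9-fold lower number from compound 1 to compound 3 (0.46 log units; beyond the scatter) and a 1.7-fold lower number from compound 2 to compound 3 (0.23 log units; within the scatter).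

Compound 4 `O=C(Nc1ccc(I)cc1)Nc1ccc2c(c1)COC2=O` continues the series with one change: iodo in place of chloro on an aromatic carbon. Both halogen steps seen so far point toward lower numbers, yet only the move from hydrogen to chloro was beyond the scatter, and even that was modest. A further small lowering in this assay is therefore expected, most likely one that stays within the scatter. The expected step is a 1.5-fold lower number from compound 3 to compound 4 (0.19 log units; within the scatter). The estimate for compound 4 in this assay is 1600 nM, within a range from 600 nM to 4200 nM.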

Compound 4, half-maximal inhibitory concentration: 1370 nM
The estimate for compound 4 lay 1.2-fold (0.07 log units) above the measured number; measured number inside the range.
By their numbers in this assay, from the lowest: compounds 4, 3, 2 and 1 (each within the scatter of the next, the first and the last beyond it).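

Iodo in place of chloro gives a 1.8-fold lower number from compound 3 to compound 4 (0.25 log units; within the scatter), so at this position on the phenyl ring the two groups cannot be told apart in this assay, yet the change does not undo what the earlier halogens gave. What is new appears at the longer range: iodo in place of fluoro gives a 3.1-fold lower number from compound 2 to compound 4 (0.49 log units; beyond the scatter), a separation that chloro did not reach against fluoro, and iodo in place of hydrogen gives a 5.2-fold lower number from compound 1 to compound 4 (0.71 log units; beyond the scatter), the largest step among these four compounds, though still a modest one. All four compounds fall in one order, hydrogen, fluoro, chloro, iodo, but each neighbouring pair lies within the scatter, so the trend rests on the ends of the series, and no measurement here explains it.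

These compounds cannot say whether the trend belongs to halogens alone or would extend to other groups at this position, such as a methyl, a methoxy, an amine or a carboxylic acid. They also leave open whether iodo would have the same effect elsewhere on the phenyl ring or on a different core.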